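From methylsulfonyl to 4-hydroxy-2-oxopiperidin-1-yl

This account rests on a few compounds, and the source may have more. Where it says the series, first, only, none or still open, it means among the compounds named here.

Measured so far in a physicochemical assay for lipophilicity, measured as octanol-water partition, at pH 7.4 (on this read-out lower numbers stand for lower lipophilicity and higher numbers for higher lipophilicity), are three compounds:
Compound 1 `CC(C)c1noc(N2CCC(Oc3cc(N4CCc5cc(N6CCCCC6=O)ccc54)ncn3)CC2)n1` gives 3.8
Compound 2 `CC(C)c1noc(N2CCC(Oc3cc(N4CCc5cc([S+]([O-])CCO)ccc54)ncn3)CC2)n1` gives 2.7
Compound 3 `CC(C)c1noc(N2CCC(Oc3cc(N4CCc5cc(S(C)(=O)=O)ccc54)ncn3)CC2)n1` gives 3.1

In this assay compound 3 stands second of the three, with compound 1 higher and compound 2 lower, both gaps beyond the scatter. Compound 4 `CC(C)c1noc(N2CCC(Oc3cc(N4CCc5cc(N6CCC(O)CC6=O)ccc54)ncn3)CC2)n1` has 4-hydroxy-2-oxopiperidin-1-yl in place of methylsulfonyl on an aromatic carbon on the shared core. Among the measured compounds shown here, two measured steps bear on this. The modest a number 0.70 log units lower from compound 1 to compound 3 (beyond the scatter) argues for a rise on returning to a ring-bearing group. For the measured compounds named here, the large a number 1.10 log units lower from compound 1 to compound 2 (beyond the scatter) leads to compound 2, which also carries a hydroxyl, though no measured pair isolates that group. A small downward step is therefore expected, estimated as a number 0.20 log units lower from compound 3 to compound 4 (within the scatter) in this reading. For compound 4 the estimated value is 2.9 within an expected range of 2.4 to 3.4 overall.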

Compound 4, distribution coefficient: 2.8
Compound 4: middle estimate off by 0.10 log units, on the high side, and the stated range covers the measured number.
By their numbers in this assay, from the lowest: compounds 2, 4 and 3 (each within the scatter of the next, the first and the last beyond it); then compound 1.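

In this assay, among the compounds shown here, hydroxy in place of hydrogen on a saturated ring carbon gives the first step that isolates that single group (a number 1.00 log units lower from compound 1 to compound 4 (beyond the scatter)). The ring-bearing 4-hydroxy-2-oxopiperidin-1-yl also cannot be told apart at this aromatic carbon from methylsulfonyl (a number 0.30 log units lower from compound 3 to compound 4 (within the scatter)) or from the open chain of compound 2 (a number 0.10 log units higher from compound 2 to compound 4 (within the scatter)). From the compounds shown here alone, whether an amine or a carboxylic acid on the same saturated ring carbon would give a step of similar size remains open. Nothing available explains these steps.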